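Swapping Fluoro for Methyl on the Amide Aryl Ring

The compounds below may be only part of what the source reports. "The series", "measured", "known", "first", "only" and "open" are said of these compounds alone.

Compound 2 `N#Cc1cc(F)cc(C(=O)Nc2cccc(F)c2)c1` gives 2160 nM in an in vitro functional assay on HEK293-A cells for antagonist activity at metabotropic glutamate receptor 5 (Rattus norvegicus), read by calcium flux; a lower number here means a stronger inhibitor, a higher number a weaker inhibitor. Of the two compounds measured, this is the highest number; compound 1 `N#Cc1cc(F)cc(C(=O)Nc2nc(C3CC3)cs2)c1` gives 900 nM, and that gap lies beyond the usual scatter. Compound 3 `Cc1cccc(NC(=O)c2cc(F)cc(C#N)c2)c1` has not yet been measured. It differs from compound 2 only by methyl in place of fluoro on an aromatic carbon, the change sitting meta to a large group. For the measured compounds named here, no measured pair shows this kind of swap, so only a modest move toward a lower number, close to the scatter, is expected. Compound 3 is estimated at 1300 nM, with a range from 500 nM to 3500 nM, an expected step of a 1.7-fold lower number from compound 2 to compound 3 (0.22 log units; within the scatter).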

Compound 3, half-maximal inhibitory concentration: 122 nM
Compound 3: middle estimate off by 11-fold (1.03 log units), on the high side, and the stated range ends above it.
By their numbers in this assay, from the lowest: compound 3; then compound 1; then compound 2.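

For the compounds shown here, on this aromatic carbon, meta to a large group, the exchange of one heavy atom matters far more than the earlier compounds could show: in this assay, methyl in place of fluoro gives an 18-fold lower number from compound 2 to compound 3 (1.25 log units; beyond the scatter) and counts as a large step. Neither group carries a ring, a hydrogen-bond donor, a hydrogen-bond acceptor or a net charge. Nothing at hand explains the size of this step. Going by these compounds, whether an ethyl, a methoxy or an amine at this same place would give a lower or a higher number stays open. So does whether this swap would give a similar step elsewhere on the ring.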